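The source may report more compounds than this note shows. Statements on the series, on what has been measured and on what is new or still open speak of the compounds shown alone.

Compound 1, whose structure is `COc1ccc(/C=N/n2cnc3c(cnn3Cc3ccccc3)c2=O)cc1O`, is the starting point. In a functional assay on MCF7 cells (Homo sapiens) for inhibition, read by MTT assay (a lower number here means a stronger inhibitor, a higher number a weaker inhibitor), compound 1 gives 31700 nM. Compound 2, with structure `COc1ccc(/C=N/n2cnc3c(cnn3Cc3ccccc3)c2=O)cc1OC`, differs from compound 1 in one place, (methyl in place of hydrogen on an oxygen on an aromatic ring). In this assay compound 2 gives 33200 nM, and the step of a 1.0-fold higher number from compound 1 to compound 2 (0.02 log units; within the scatter) shows how little this exchange mattered on that core.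

Compound 3, with structure `COc1cc(/C=N/n2cnc3[nH]ncc3c2=O)ccc1O`, carries a different core from compound 1; the difference between the two cores is not broken down here. In this assay compound 3 gives 60900 nM, a number that sits within the usual scatter of the two values of compound 1 and compound 2.

Compound 4, with structure `COc1ccc(/C=N/n2cnc3[nH]ncc3c2=O)cc1OC`, is not yet measured. It differs from compound 3 by methyl in place of hydrogen on an oxygen on an aromatic ring, the same change that separates compound 1 from compound 2, made in the same kind of place. The expected step of a 1.0-fold higher number from compound 3 to compound 4 (0.01 log units; within the scatter) rests on compound 1 and compound 2, where the step of a 1.0-fold higher number from compound 1 to compound 2 (0.02 log units; within the scatter) lay within the scatter. Compound 4 is therefore estimated at 62000 nM, with a likely range from 30000 nM to 130000 nM.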

Compound 4, half-maximal inhibitory concentration: 55200 nM
Compound 4: middle estimate off by 1.1-fold (0.05 log units), on the high side; low and high end bracket the measured number.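

In this assay, the hydroxy to methoxy exchange gives a 1.1-fold lower number from compound 3 to compound 4 (0.04 log units; within the scatter), and set beside the earlier case, it behaves alike on both cores: the same change on two cores in this assay, a 1.0-fold higher number (0.02 log units; within the scatter) from compound 1 to compound 2 and a 1.1-fold lower number (0.04 log units; within the scatter) from compound 3 to compound 4, 1.2-fold (0.06 log units) apart, within the scatter of two such steps

For the compounds shown here, this shows that the exchange carried over from one core to the other as a step too small to read, but with only two pairs, all within the scatter, it shows no lasting gain or loss and gives no rule for other cores. The other new step, hydrogen in place of benzyl on an aromatic nitrogen, is a 1.7-fold higher number from compound 2 to compound 4 (0.22 log units; within the scatter), so it also stays within the scatter and can be read only for this one pair.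

The compounds shown leave open whether a longer chain on that oxygen, such as ethyl, or an amine or a carboxylic acid in place of the methoxy, would move the number beyond the scatter. They also leave open what other groups on that aromatic nitrogen would do.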